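The source may hold more compounds than are shown below. What is called first, only, known or untested is meant among the compounds shown, and "the series" means these compounds.

Working notes on the series. Compound 1 `COc1cc(C)c(S(=O)(=O)N(C)CCOCC(=O)N2CCN([C@H]3CN4CCC3CC4)CC2)c(C)c1` is the anchor for this step. For the measured compounds named here, in an ADME assay on Caco-2 cells (Homo sapiens) for permeability, tested at 50 uM (a higher number here means that the compound crosses the layer faster, a lower number that the compound crosses the layer more slowly), compound 1 gives 1.9 10^-6 cm/s, the second highest of the three numbers so far. Compound 2 `COc1cc(C)c(S(=O)(=O)N(C)CCOCC(=O)N2CCC(C3CCN(C(C)C)CC3)CC2)c(C)c1` gives 3 10^-6 cm/s in this assay, and compound 3 `COc1cc(C)c(S(=O)(=O)N(C)CCOCC(=O)N2CCC(C(O)CN(C)C)CC2)c(C)c1` gives 1.3 10^-6 cm/s; compound 1 lies within the scatter of both, so no order among the three can be claimed. Going by the values given here, the single one-place step measured is a 2.3-fold lower number from compound 2 to compound 3 (0.36 log units; beyond the scatter), where a ring-bearing amine was exchanged for a short open-chain amine on the saturated end of the molecule.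

Compound 4 `COc1cc(C)c(S(=O)(=O)N(C)CCOCC(=O)N2CCN(CCN(C)C)CC2)c(C)c1` is not yet measured. It differs from compound 1 in this way: a group of 5 heavy atoms (4 carbon, 1 nitrogen; no ring) in place of a group of 8 heavy atoms (7 carbon, 1 nitrogen; 2 six-membered non-aromatic rings with 1 hetero atom each), on an amine nitrogen in a ring. The exchange runs in the same sense as the step already measured, a group with rings giving way to a short chain. Because a 2.3-fold lower number from compound 2 to compound 3 (0.36 log units; beyond the scatter) went downward on that exchange, a modest lowering is expected for compound 4 in this assay, with no rise anticipated. For compound 4 the estimated value is 1.4 10^-6 cm/s, range 0.7 10^-6 cm/s to 3 10^-6 cm/s. That is an expected step of a 1.4-fold lower number from compound 1 to compound 4 (0.13 log units; within the scatter).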

Compound 4, apparent permeability: 2.1 10^-6 cm/s
Estimate against measurement, compound 4: 1.5-fold (0.18 log units) below, within the range that was stated.
By their numbers in this assay, from the lowest: compounds 3, 1, 4 and 2 (each within the scatter of the next, the first and the last beyond it).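

On an amine nitrogen in a ring, 2-(dimethylamino)ethyl in place of the group with two six-membered non-aromatic rings and one defined stereocentre gives a 1.1-fold higher number from compound 1 to compound 4 (0.04 log units; within the scatter) in this assay. At this position, then, the rings and the stereocentre can give way to an open chain with no step beyond the scatter, whereas the exchange on a saturated ring carbon gave a 2.3-fold lower number from compound 2 to compound 3 (0.36 log units; beyond the scatter), so a single ring-to-chain outcome does not hold across the two places. Nothing measured here offers a reason for this difference.

Open, from the compounds shown here alone, is whether a longer chain such as 3-(dimethylamino)propyl, or a carboxylic acid on the same amine nitrogen, would stay within the scatter of compound 1 in this assay. Also open, going by these compounds, is how a primary amine at the end of the chain would read there.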